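The source may hold more compounds than are shown below. What is called first, only, known or untested is meant among the compounds shown, and "the series" means these compounds.

Compound 1 `Cc1ccc(CCc2cc3cn([C@H]4C[C@H](O)[C@@H](CO)O4)c(=O)nc3o2)cc1`: 540000 nM in an ADME assay on HEL cells (Homo sapiens) for cytotoxicity, with a stated time of 3 days; a higher number here means that more compound is tolerated, a lower number that less compound is tolerated.
Compound 2 `O=c1nc2oc(C#Cc3ccccc3)cc2cn1[C@H]1C[C@H](O)[C@@H](CO)O1`: in this assay compound 2 reached only the limit > 570000 nM, so no exact number is known for it.

Compound 2 thus stands at the edge of what this assay can report, the point where (the limit of > 570000 nM in this assay, at which 1 of the 2 values shown sits). Among the measured compounds shown here, the one measured step, an at least 1.0-fold higher number from compound 1 to compound 2 (0.02 log units; that floor lies within the scatter), is a change too small to count, and both measured compounds sit in the same region of tolerated concentration.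

Compound 3 `O=c1nc2oc(CCc3ccccc3)cc2cn1[C@H]1C[C@H](O)[C@@H](CO)O1` is the next compound. It differs from compound 2 by phenethyl in place of 2-phenylethynyl on an aromatic carbon. For the measured compounds named here, the only measured step that bears on this change is an at least 1.0-fold higher number from compound 1 to compound 2 (0.02 log units; that floor lies within the scatter), which lies within the scatter, and compound 1 gives 540000 nM, a value close to where compound 2 stands. Nothing in these numbers points to a movement in either direction beyond the scatter, so the expected step is an at least 1.0-fold lower number from compound 2 to compound 3 (0.00 log units; that floor lies within the scatter). Compound 3 is therefore estimated at 560000 nM in this assay, with a likely range from 300000 nM to 1100000 nM, and a real chance that this assay again reports only a limit.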

Compound 3, minimum cytotoxic concentration: > 560000 nM
Compound 3 was reported as a limit; the forecaster's own chance of this, stated with the estimate: 50%; the middle value lies on the limit itself.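

With phenethyl in place of 2-phenylethynyl on the same aromatic carbon, compound 3 also reaches only a limit in this assay, so the saturated chain and the triple-bonded one both leave the reading at the edge of what can be reported: the limit of > 560000 nM in this assay, at which 1 of the 3 values shown sits. The two limits leave the step between compound 2 and compound 3 unreadable, so no size can be given for swapping the triple bond out of this chain. The new comparison that can be read is hydrogen in place of methyl on an aromatic carbon, which gives an at least 1.0-fold higher number from compound 1 to compound 3 (0.01 log units; that floor lies within the scatter) and therefore shows no change that counts from removing this methyl group.

The limits leave open how much compound could be tolerated beyond the reported concentrations, and whether compound 2 and compound 3 truly differ there. On these data alone, it also remains open whether an amine or a carboxylic acid on the phenyl ring, or a longer chain in place of phenethyl, would bring the tolerated concentration down to a value that can be read as an exact number.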